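A few compounds are considered here, and "the series" means these few. Any claim that something is new, unique, unknown or untested is made for them only; others in the source may bear on it.

Compounds measured in a functional assay on MDA-MB-231 cells (Homo sapiens) for antiproliferative activity, read by sulforhodamine B assay, with a stated time of 48 h, tested at 10 uM; a lower number here means less inhibition, a higher number more inhibition at the concentration tested (going by the name of the read-out):
compound 1, `CCCCCCCCCCCCCC[C@H](OCOC)[C@H](CN(CC)CC)NC(=O)OC(C)(C)C`, 0.84%
compound 2, `CCCCCCCCCCCCCC[C@H](OCOC)[C@H](CN(CCCC)CCCC)NC(=O)OC(C)(C)C`, 22.3%
compound 3, `CCCCCCCCCCCCCC[C@H](OCOC)[C@H](CN1CCCCC1)NC(=O)OC(C)(C)C`, 9.84%

Compound 1 gives the lowest of the three numbers in this assay; compound 3 sits closest, a step of a number 9 percentage points higher from compound 1 to compound 3 (within the scatter), while compound 2 is furthest, at a number 21.5 percentage points higher from compound 1 to compound 2 (beyond the scatter). Compound 4, `CCCCCCCCCCCCCC[C@H](O)[C@H](CN(CC)CC)NC(=O)OC(C)(C)C`, differs from compound 1 by hydrogen in place of methoxymethyl on an oxygen on a saturated carbon. For the measured compounds named here, none of the measured steps touches this part of the molecule; all three change only the amine. Going by the values given here, no measured step therefore bears on the change to compound 4, and the expectation rests on the change being small and remote from the varied amine. An expected step of a number 4.2 percentage points higher from compound 1 to compound 4 (within the scatter), not beyond the scatter, follows. Compound 4 is estimated at 5%, between -8% and 20%.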

Compound 4, a percentage reported as inhibition, at one concentration (the size of the read-out at that concentration, not a potency): -1.45%
Estimate against measurement, compound 4: 6.5 percentage points above; the range from low to high includes it.
By their numbers in this assay, from the lowest: compounds 4, 1 and 3 (each within the scatter of the next, the first and the last beyond it); then compound 2.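

The methoxymethoxy to hydroxy change is the first shown away from the amine, and a number 2.3 percentage points lower from compound 1 to compound 4 (within the scatter) in this assay places it within the scatter. With diethylamino as the amine, removing methoxymethyl from this oxygen therefore produces no step beyond the scatter. No measurement here offers an explanation for this result.

From the compounds shown here alone, whether hydroxy behaves the same way alongside the dibutylamino group of compound 2 stays open. So does the outcome with a methyl or acetyl group on that oxygen.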